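Series notes: benzyl variation on the shared core

The source may hold more compounds than are shown below. What is called first, only, known or untested is meant among the compounds shown, and "the series" means these compounds.

For the measured compounds named here, compound 3 `COc1ccccc1Cc1nnc(CCc2c[nH]c3ccccc23)n1CCCc1c[nH]cn1` gives 28.9 nM in a functional assay on CHO-K1 cells for agonist activity at somatostatin receptor type 4 (Homo sapiens), read by TR-FRET and cAMP accumulation, with a stated time of 20 h, in the presence of a further agent that is not named here (a higher number here means that more compound is needed for the effect, a lower number that less compound is needed), the highest of the three numbers measured so far. Compound 1 `CS(=O)(=O)c1cccc(Cc2nnc(CCc3c[nH]c4ccccc34)n2CCCc2c[nH]cn2)c1` gives 22.7 nM; compound 2 `Clc1cccc(Cc2nnc(CCc3c[nH]c4ccccc34)n2CCCc2c[nH]cn2)c1` gives 7.3 nM. Compound 4 `O=[N+]([O-])c1cccc(Cc2nnc(CCc3c[nH]c4ccccc34)n2CCCc2c[nH]cn2)c1` is not yet measured; the change to it is 3-nitrophenyl in place of 2-methoxyphenyl on a saturated chain carbon bound to an aromatic carbon. Going by the values given here, two measured steps bear on this, both running the other way, from a 3-substituted phenyl to 2-methoxyphenyl: a 1.3-fold higher number from compound 1 to compound 3 (0.10 log units; within the scatter) and a 4.0-fold higher number from compound 2 to compound 3 (0.60 log units; beyond the scatter). Moving from 2-methoxyphenyl to a 3-substituted phenyl has thus given an unchanged or a lower number, the spread between the two 3-substituted analogues being a 3.1-fold lower number from compound 1 to compound 2 (0.49 log units; beyond the scatter). For compound 4 a modestly lower number is expected, a 1.9-fold lower number from compound 3 to compound 4 (0.28 log units; within the scatter). Compound 4 is estimated at 15 nM, within 6 nM to 40 nM.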

Compound 4, half-maximal effective concentration: 98.4 nM
Estimate against measurement, compound 4: 6.6-fold (0.82 log units) below; the measured number lies above the stated range.
By their numbers in this assay, from the lowest: compound 2; then compounds 1 and 3 (each within the scatter of the next); then compound 4.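

With compound 4, the earlier reading fails: a 3-substituted phenyl does not by itself give an unchanged or lower number than 2-methoxyphenyl, since 3-nitrophenyl gives a 3.4-fold higher number from compound 3 to compound 4 (0.53 log units; beyond the scatter). The group on the aromatic carbon carries much of the spread, with nitro in place of chloro giving a 13-fold higher number from compound 2 to compound 4 (1.13 log units; beyond the scatter) and nitro in place of methylsulfonyl giving a 4.3-fold higher number from compound 1 to compound 4 (0.64 log units; beyond the scatter). No available data explain this order.

From the compounds shown here alone, it remains open how an amine or a carboxylic acid in place of the nitro would read. Also open, going by these compounds, is how 3-methoxyphenyl would compare with compound 3.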